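Methyl for nitro on the aryl ring of a thiazolylidene hydrazide

The source may report more compounds than this note shows. Statements on the series, on what has been measured and on what is new or still open speak of the compounds shown alone.

Three analogues of one shared core have been tested in a functional assay on C6 cells (Rattus norvegicus) for cytotoxicity, read by MTT assay, with a stated time of 24 h, tested at 6 ug/mL; a higher number here means a weaker effect of the compound at the concentration tested, a lower number a stronger effect. Compound 1 `Cc1ccc(-c2cs/c(=N/NC(=O)CSc3nnnn3-c3ccccc3)n2-c2ccccc2)cc1` gives 66.8%. Within the data shown here, compound 2 `O=C(CSc1nnnn1-c1ccccc1)N/N=c1/scc(-c2ccc(Cl)cc2)n1-c1ccccc1` gives 77.4%, and the only single-point step among the measured compounds, a number 10.6 percentage points higher from compound 1 to compound 2 (beyond the scatter), shows a number moving upward by more than the scatter. Compound 3 `Cn1nnnc1SCC(=O)N/N=c1/scc(-c2ccc([N+](=O)[O-])cc2)n1-c1ccccc1` gives 80.4%, the highest of the three numbers; it sits within the scatter of compound 2 and beyond the scatter above compound 1.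

Compound 4 `Cc1ccc(-c2cs/c(=N/NC(=O)CSc3nnnn3C)n2-c2ccccc2)cc1` has not been measured. It differs from compound 3 in one place: methyl in place of nitro on an aromatic carbon. Among the measured compounds shown here, no measured pair carries this exact change. The nearest guide is that a methyl on the same aryl ring, in compound 1, goes with the lowest number, 66.8%, while replacing that methyl by chloro in compound 2 raised the number by a number 10.6 percentage points higher from compound 1 to compound 2 (beyond the scatter); compound 3, with nitro and a methyl on its tetrazole, stands higher still. On that basis a downward step is expected for compound 4, estimated at a number 10.4 percentage points lower from compound 3 to compound 4 (beyond the scatter), modest and near the edge of the scatter. In this assay compound 4 is therefore expected to give about 70%, between 58% and 82%.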

Compound 4, a percentage reported as activity, at one concentration (the size of the read-out at that concentration, not a potency): 88%
The estimate for compound 4 lay 18 percentage points below the measured number; the measured number lies above the stated range.
By their numbers in this assay, from the lowest: compound 1; then compounds 2, 3 and 4 (each within the scatter of the next, the first and the last beyond it).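

The exchange of 4-nitrophenyl to 4-methylphenyl, on an aromatic carbon para to a large group, gives a number 7.6 percentage points higher from compound 3 to compound 4 (within the scatter) in this assay, so with a methyl on the aromatic nitrogen, nitro and methyl on the aryl ring cannot be told apart in this pair. Among these compounds, the other new step, methyl in place of phenyl on an aromatic nitrogen, gives a number 21.2 percentage points higher from compound 1 to compound 4 (beyond the scatter), and it is the first sign that the group on that nitrogen can move the number by more than the scatter while the 4-methylphenyl stays the same. Nothing given here accounts for either step.

On these data alone, it remains open whether an amine or a carboxylic acid on the same aromatic carbon would shift the number beyond the scatter, and whether nitro and methyl would also stay within the scatter of each other with phenyl on the aromatic nitrogen. As far as these compounds go, it is equally open whether an ethyl or a longer chain on that nitrogen would read like methyl or like phenyl.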